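The compounds below may be only part of what the source reports. "The series", "measured", "known", "first", "only" and "open" are said of these compounds alone.

Compound 2 `O=C(O)c1ccc2oc(-c3ccc(Cl)cc3)c(O)c(=O)c2c1` gives -19% in a functional assay on the whole organism (stomach) for inhibition, with Rattus norvegicus as the target, at a dose of 80 mg/kg (a lower number here means less inhibition, a higher number more inhibition at the dose given (going by the name of the read-out)), the lowest of the three numbers measured. Compound 1 `COc1ccc(-c2oc3ccc(C(=O)O)cc3c(=O)c2O)cc1` gives 24% and compound 3 `O=C(O)c1ccc(-c2oc3ccc(C(=O)O)cc3c(=O)c2O)cc1` gives 23%, the two lying within the scatter of each other. The steps between the measured compounds are large where they involve compound 2: a number 43 percentage points lower from compound 1 to compound 2 (beyond the scatter) and a number 42 percentage points higher from compound 2 to compound 3 (beyond the scatter), both a change on an aromatic carbon, while a number 1 percentage points lower from compound 1 to compound 3 (within the scatter). Compound 4 `COc1c(-c2ccc(Cl)cc2)oc2ccc(C(=O)O)cc2c1=O` differs from compound 2 at a different place: methyl in place of hydrogen on an oxygen on an aromatic ring. Among the measured compounds shown here, no measured step touches this oxygen, so none of the three bears on the change, and its size is uncertain. Compound 4 is therefore estimated at -10% in this assay, with a range of -40% to 20%. The expected step is a number 9 percentage points higher from compound 2 to compound 4 (within the scatter), not clearly beyond the scatter.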

Compound 4, a percentage reported as inhibition, in the whole organism at one dose (the size of the read-out at that dose, not a potency): 34%
Compound 4: middle estimate off by 44 percentage points, on the low side; the whole stated range lies below it.
By their numbers in this assay, from the lowest: compound 2; then compounds 3, 1 and 4 (each within the scatter of the next, the first and the last beyond it).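

In this assay, the change from hydroxy to methoxy gives a number 53 percentage points higher from compound 2 to compound 4 (beyond the scatter). Among the compounds shown here, the earlier large steps all lay on an aromatic carbon, so this is the first sign that the oxygen on the aromatic ring is also a place where one small change moves the read-out beyond the scatter. No measurement given here accounts for the step.

For the compounds shown here, the step is seen only with chloro on the aromatic carbon, so it remains open whether it would recur with methoxy or carboxy there. Also open, from the compounds shown here alone, is how an ethyl or acetyl group on this oxygen would compare with methyl.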